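A few compounds are considered here, and "the series" means these few. Any claim that something is new, unique, unknown or untested is made for them only; others in the source may bear on it.

Of the compounds shown here, two built on a shared core have been measured in a functional assay on NCI-H460 cells (Homo sapiens) for cytotoxicity, read by MTT assay, with a stated time of 72 h; on this read-out higher numbers stand for weaker inhibition and lower numbers for stronger inhibition. Compound 1 `CN(C)CCn1cnnc1-c1cc(Oc2ccc(NC(=O)N/N=C/c3cc(C(C)(C)C)cc(C(C)(C)C)c3O)cc2F)ccn1` gives 590 nM, while compound 2 `CN(C)CCn1cnnc1-c1cc(Oc2ccc(NC(=O)N/N=C/c3ccc(F)cc3)cc2F)ccn1` gives 1980 nM. Among the compounds with values here, of these two numbers, compound 2 stands highest, and its only neighbour is compound 1, whose number lies beyond the usual scatter below it. The next compound, compound 3 `CN(C)CCn1cnnc1-c1cc(Oc2ccc(NC(=O)N/N=C/c3ccc(F)cc3Cl)cc2F)ccn1`, differs from compound 2 in one place: chloro in place of hydrogen on an aromatic carbon. Within the data shown here, no pair of measured compounds isolates this change, so no directly comparable step is known. Still, a chloro group entering ortho to a large group on a six-membered aromatic ring of carbon only is a small change, and the expectation is a modest step of a 1.7-fold lower number from compound 2 to compound 3 (0.22 log units; within the scatter), toward a lower number rather than a higher one. Compound 3 is therefore expected to give 1200 nM, within a range from 500 nM to 3000 nM.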

Compound 3, half-maximal inhibitory concentration: 720 nM
Estimate against measurement, compound 3: 1.7-fold (0.22 log units) above; the range from low to high includes it.
By their numbers in this assay, from the lowest: compounds 1 and 3 (each within the scatter of the next); then compound 2.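

In this assay the change from 4-fluorophenyl to 2-chloro-4-fluorophenyl brings a 2.8-fold lower number from compound 2 to compound 3 (0.44 log units; beyond the scatter) and this step lies beyond the usual scatter. It is the first measured change in a single place among these compounds, and it shows that this aromatic carbon, ortho to a large group and meta to the fluoro group, is not indifferent: one chlorine atom in place of hydrogen is enough to shift the number by more than repeat measurements would. No measurement at hand gives a reason for this shift.

On these data alone, whether a different group on the same carbon, such as methyl, methoxy or an amine, would shift the number in the same way remains open. As far as these compounds go, it is also open whether chloro would do the same on another carbon of this ring.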